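The source may hold more compounds than are shown below. What is called first, only, known or untested is meant among the compounds shown, and "the series" means these compounds.

Measured so far:
Compound 1, `COC(=O)NCC1Cc2ccc(NC(=O)c3cccc(C)c3-c3ccc(C(F)(F)F)cc3)cc2C1`: 4.1 nM in an assay for inhibition of apolipoprotein B-100 (Homo sapiens), tested at 100 nM; a lower number here means a stronger inhibitor, a higher number a weaker inhibitor
Compound 2, `COC(=O)NCC1Cc2ccc(NC(=O)c3cc(C)cc(C)c3-c3ccc(C(F)(F)F)cc3)cc2C1`: 2.2 nM
Compound 3, `COC(=O)NC1CCc2ccc(NC(=O)c3cccc(C)c3-c3ccc(C(F)(F)F)cc3)cc2CC1`: 1.6 nM

All three compounds share an amide linking a benzamide, carrying a 4-(trifluoromethyl)phenyl group, to a bicyclic amine bearing a methyl carbamate. Compound 1 and compound 2 share one core; compound 3 has a different core, and the difference between the two cores is not broken down here. Compound 3 gives a lower number than compound 1, while compound 3 and compound 2 give numbers that cannot be told apart.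

The change from compound 1 to compound 2 is methyl in place of hydrogen on an aromatic carbon. This gave a 1.9-fold lower number from compound 1 to compound 2 (0.27 log units; within the scatter).

Compound 4, `COC(=O)NC1CCc2ccc(NC(=O)c3cc(C)cc(C)c3-c3ccc(C(F)(F)F)cc3)cc2CC1`, is still to be measured. It differs from compound 3 by methyl in place of hydrogen on an aromatic carbon. The place of the change is described in the same words for both pairs, so this is the same change applied to the other core.

Among the compounds with values here, the step from compound 3 to compound 4 is expected to be a 1.6-fold lower number from compound 3 to compound 4 (0.20 log units; within the scatter), roughly as small as the earlier one, because the only comparable step, a 1.9-fold lower number from compound 1 to compound 2 (0.27 log units; within the scatter), lay within the scatter. Since a single example cannot show whether the second core responds in the same way, the range is kept wide. Compound 4 is therefore expected to give about 1 nM, somewhere between 0.45 nM and 2.4 nM.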

Compound 4, half-maximal inhibitory concentration: 2.4 nM
For compound 4 the middle estimate is 2.4-fold (0.38 log units) below the measured one; the range from low to high includes it.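

In this assay, putting methyl in place of hydrogen on an aromatic carbon of compound 3 gave a 1.5-fold higher number from compound 3 to compound 4 (0.18 log units; within the scatter), so on this core the change has no clear effect when the step is read alone. Set beside the step on the other core, however, the same change does not behave alike on the two cores, since the two steps point in opposite directions and the gap between them is larger than chance scatter would readily explain: the same change on two cores in this assay, a 1.9-fold lower number (0.27 log units; within the scatter) from compound 1 to compound 2 and a 1.5-fold higher number (0.18 log units; within the scatter) from compound 3 to compound 4, 2.8-fold (0.45 log units) apart, beyond the scatter of two such steps

This shows that the effect of the methyl cannot simply be assumed to carry over from one core to the other, but it rests on a single pair per core and on two steps that are each small, and it does not show why the cores differ or whether the gap would hold up in further pairs.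

The compounds shown leave open how a group other than methyl at this place, such as a longer chain, an amine or a carboxylic acid, would behave on either core. They also leave open whether the two cores would still differ if the methyl carbamate shared by all four compounds gave way to another group, such as a simple amide.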